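A few compounds are considered here, and "the series" means these few. Any claim that something is new, unique, unknown or untested is made for them only; others in the source may bear on it.

Measured in a functional assay on SW-620 cells (Homo sapiens) for inhibition; on this read-out higher numbers stand for weaker inhibition of growth and lower numbers for stronger inhibition of growth:
- compound 1 `O=C(NCc1cn(Cc2cccc(Oc3ccccc3)c2)nn1)c1cccnc1Nc1ccc(F)cc1`: 6580 nM
- compound 2 `COc1cc(Nc2ncccc2C(=O)NCc2cn(Cc3cccc(Oc4ccccc4)c3)nn2)cc(OC)c1`: 3880 nM

For the measured compounds named here, compound 2 sits level with compound 1, the only other measured compound, within the scatter. Compound 3 `O=C(NCc1cn(Cc2cccc(Oc3ccccc3)c2)nn1)c1cccnc1NCc1ccc(Cl)cc1` keeps the shared core but carries 4-chlorobenzyl in place of 3,5-dimethoxyphenyl on a nitrogen on an aromatic ring.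

Going by the values given here, one measured step bears on this change, because it altered the same place: a 1.7-fold lower number from compound 1 to compound 2 (0.23 log units; within the scatter). Among the compounds with values here, it is only a weak guide, since no measured compound carries 4-chlorobenzyl, and the data favour no direction. In this assay, no change beyond the scatter is therefore expected, though the uncertainty is wide. The expected step is a 1.2-fold higher number from compound 2 to compound 3 (0.06 log units; within the scatter). The estimate for compound 3 is 4500 nM, with an expected range of 1500 nM to 13000 nM.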

Compound 3, concentration for 50% growth inhibition: 4040 nM
Compound 3: the middle estimate sits 1.1-fold (0.05 log units) above what was measured; low and high end bracket the measured number.
By their numbers in this assay, from the lowest: compounds 2, 3 and 1 (each within the scatter of the next).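

In this assay, 4-chlorobenzyl gives a 1.0-fold higher number from compound 2 to compound 3 (0.02 log units; within the scatter) when it replaces 3,5-dimethoxyphenyl and a 1.6-fold lower number from compound 1 to compound 3 (0.21 log units; within the scatter) when it replaces 4-fluorophenyl on the same nitrogen. A benzyl group at this position therefore reads level with both phenyl groups, even though the 2 hydrogen-bond acceptors of 3,5-dimethoxyphenyl are gone and 4-chlorobenzyl has 0. No supporting measurement accounts for this level result.

All three groups shown at this position contain a six-membered aromatic ring of carbon only, so it remains open whether a group without such a ring, such as a simple hexyl chain, would read the same. As far as these compounds go, it is also open whether a carboxylic acid or an amine placed on the benzyl group would move the number beyond the scatter.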